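A few compounds are considered here, and "the series" means these few. Any claim that something is new, unique, unknown or untested is made for them only; others in the source may bear on it.

Measured so far in a functional assay on HCT-116 cells (Homo sapiens) for inhibition, read by MTT assay, with a stated time of 72 h (a higher number here means a weaker inhibitor, a lower number a stronger inhibitor), are three compounds:

Compound 1 `O=C1/C(=C\c2ccccc2)c2c(ncn2COCc2ccccc2)CCN1Cc1ccccc1` gives 20000 nM
Compound 2 `Cc1cccc(CN2CCc3ncn(COCc4ccccc4)c3/C(=C/c3ccccc3)C2=O)c1` gives 3800 nM
Compound 3 `Cc1ccccc1CN1CCc2ncn(COCc3ccccc3)c2/C(=C/c2ccccc2)C1=O` gives 24700 nM

Compound 1 sits at the high, weak end of these numbers, level with compound 3 and above compound 2. Compound 4 `COc1cc(/C=C2\C(=O)N(Cc3ccccc3)CCc3ncn(COCc4ccccc4)c32)cc(OC)c1OC` carries 3,4,5-trimethoxyphenyl in place of phenyl on a double-bonded chain carbon bound to a double-bonded ring carbon. Within the data shown here, no measured step touches that place. Among the measured compounds shown here, the only guides are methyl changes at another place, where a 5.3-fold lower number from compound 1 to compound 2 (0.72 log units; beyond the scatter) is modest and a 1.2-fold higher number from compound 1 to compound 3 (0.09 log units; within the scatter) stays within the scatter. A modest step toward a lower number in this assay is therefore expected, though only loosely. The expected step is a 2.5-fold lower number from compound 1 to compound 4 (0.40 log units; beyond the scatter). The estimate for compound 4 is 8000 nM, with an expected range from 1500 nM to 30000 nM.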

Compound 4, half-maximal inhibitory concentration: 8900 nM
Beside the measured number, compound 4's estimate is 1.1-fold (0.05 log units) below it, and the stated range covers the measured number.
By their numbers in this assay, from the lowest: compound 2; then compound 4; then compounds 1 and 3 (each within the scatter of the next).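

In this assay, this is the first change shown at the place on a double-bonded chain carbon bound to a double-bonded ring carbon: 3,4,5-trimethoxyphenyl in place of phenyl gives a 2.2-fold lower number from compound 1 to compound 4 (0.35 log units; beyond the scatter). So this place also affects the read-out, and a group with 12 heavy atoms and 3 hydrogen-bond acceptors, replacing one with 6 heavy atoms and 0 acceptors, keeps the compound in the measurable range. No supporting measurement is available to explain this shift.

From the compounds shown here alone, it remains open which of the methoxy groups matter, and whether a single hydroxyl or an amine on that phenyl would do the same. Also open, going by these compounds, is whether this change would add to the 3-methylphenyl group of compound 2.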